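The source may report more compounds than this note shows. Statements on the series, on what has been measured and on what is new or still open speak of the compounds shown alone.

Working notes on the series. Of the compounds shown here, two have numbers so far in a functional assay; on this read-out lower numbers stand for stronger inhibition and higher numbers for weaker inhibition. Compound 1 (`Cc1c(/N=C/c2cc(O)ccc2O)c(=O)n(-c2ccccc2)n1C`) gives 17100 nM, and compound 2 (`C/C(=N\c1c(C)n(C)n(-c2ccccc2)c1=O)c1ccc(O)cc1O`) gives 19100 nM. These two values lie within the scatter of each other, so compound 2 stands level with compound 1 on the available numbers.

Compound 3 (`C/C(=N\c1c(C)n(C)n(-c2ccccc2)c1=O)c1cc(O)ccc1O`) has not yet been measured and differs from compound 2 in one group: 2,5-dihydroxyphenyl in place of 2,4-dihydroxyphenyl on a carbon with a double bond to nitrogen. Within the data shown here, no step between measured compounds isolates this change, so its size has no direct precedent. Among the measured compounds shown here, the only guide is compound 1, which also carries the 2,5-dihydroxyphenyl group and gives 17100 nM, within the scatter of the value for compound 2. On that limited evidence, no step beyond the scatter is expected in this assay, in either direction. The estimated change is small, expressed as a 1.2-fold lower number from compound 2 to compound 3 (0.08 log units; within the scatter). The expected value for compound 3 is 16000 nM, with an estimated range of 6000 nM to 42000 nM.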

Compound 3, half-maximal inhibitory concentration: 15200 nM
Beside the measured number, compound 3's estimate is 1.1-fold (0.02 log units) above it, and the stated range covers the measured number.
By their numbers in this assay, from the lowest: compounds 3, 1 and 2 (each within the scatter of the next).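

Among these compounds, the direct pair in this assay gives a 1.3-fold lower number from compound 2 to compound 3 (0.10 log units; within the scatter), the only step so far that isolates the exchange of 2,4-dihydroxyphenyl for 2,5-dihydroxyphenyl on a carbon with a double bond to nitrogen. The earlier compounds shown here could only hint at this comparison, whereas this pair, with the same atoms joined differently and the rest of the structure held constant, shows that the exchange does not separate the two compounds on this read-out. Nothing at hand bears on why the two groups read alike, so the result stays a plain observation about these two compounds.

From the compounds shown here alone, with only these two dihydroxyphenyl groups compared at this place, it remains open whether the hydroxyl groups matter at all, and a plain phenyl, a methoxyphenyl or an aminophenyl group on the same carbon would address that question. Going by these compounds, it is also open whether any change at this place can move the number in this assay beyond the scatter, or whether such a shift would have to come from elsewhere on the shared core.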